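Furan-2-yl for Phenyl on the Oxadiazole Side Chain

A few compounds are considered here, and "the series" means these few. Any claim that something is new, unique, unknown or untested is made for them only; others in the source may bear on it.

Measured compounds:
compound 1 `O=C(O)CCc1ccc(OCc2nc(-c3ccccc3)no2)cc1` — 1130 nM
compound 2 `O=C(O)CCc1ccc(OCc2nc(-c3ccc(C(F)(F)F)cc3)no2)cc1` — 610 nM

Both compounds were tested in a functional assay on CHO cells for agonist activity at Free fatty acid receptor 1 (Homo sapiens), read by FLIPR and calcium flux, in the presence of a further agent that is not named here; a lower number here means that less compound is needed, a higher number that more compound is needed for the effect. Compound 1 gives 1130 nM, the highest of the two numbers; its nearest neighbour is compound 2, which gives 610 nM. Within the data shown here, the one measured step, a 1.9-fold lower number from compound 1 to compound 2 (0.27 log units; within the scatter), lies within the scatter, so the two values show no real difference.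

Compound 3 `O=C(O)CCc1ccc(OCc2nc(-c3ccco3)no2)cc1` is not yet measured. It differs from compound 1 as follows: furan-2-yl in place of phenyl on an aromatic carbon.

Among the measured compounds shown here, no measured step bears on this change. The step from compound 1 to compound 2 altered a substituent on the phenyl ring rather than exchanging the ring itself, and it stayed within the scatter. The measured data therefore offer no direction for the exchange of phenyl for furan-2-yl. For compound 3 the number is expected to stay close to that of compound 1, with no step beyond the scatter anticipated: a 1.3-fold higher number from compound 1 to compound 3 (0.12 log units; within the scatter). The estimate for compound 3 is 1500 nM, with a range from 500 nM to 4500 nM.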

Compound 3, half-maximal effective concentration: > 100000 nM
Compound 3 ended at the assay's limit (the forecaster's own chance of this, stated with the estimate: 10%); middle value at least 66-fold (1.82 log units) from the limit.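

In this assay, exchanging the ring itself on the aromatic carbon of the five-membered aromatic ring with 2 nitrogen and 1 oxygen gives an at least 88-fold higher number from compound 1 to compound 3 (1.94 log units; beyond the scatter), whereas adding trifluoromethyl to the phenyl ring gave only a 1.9-fold lower number from compound 1 to compound 2 (0.27 log units; within the scatter). The value of compound 3 is a limit of the assay and not a number: the limit of > 100000 nM in this assay, at which 1 of the 3 values shown sits. This position is therefore not indifferent to the ring it carries, since furan-2-yl, with one heavy atom fewer than phenyl and one hydrogen-bond acceptor where phenyl has none, gives a large step where the substituent on phenyl gave none beyond the scatter.

The compounds shown leave open whether the step goes with the ring oxygen of furan-2-yl or with the five-membered ring as such, and a thiophen-2-yl or a pyridin-3-yl group at this position would bear on that question. They also leave open whether a substituent such as trifluoromethyl or chlorine on the furan-2-yl ring would change the reading of compound 3 in this assay.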